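Amide aryl changes on the shared core: paw edema inhibition

A few compounds are considered here, and "the series" means these few. Any claim that something is new, unique, unknown or untested is made for them only; others in the source may bear on it.

compound 1 `COc1cc2c(cc1OC)C(CC(=O)Nc1ccc(Cl)cc1)CC2` — 4.69%
compound 2 `COc1cc2c(cc1OC)C(CC(=O)Nc1cccc(C)c1)CC2` — 20.7%

In a functional assay on the whole organism (strain Wistar) for inhibition, with Rattus norvegicus as the target, read by paw edema, at a dose of 100 mg/kg by the oral route (a higher number here means more inhibition at the dose given (going by the name of the read-out), a lower number less inhibition), compound 1 gives 4.69% and compound 2 gives 20.7%. Compound 2 thus stands highest of the two numbers, with compound 1 nearest. For the measured compounds named here, the one measured step, a number 16 percentage points higher from compound 1 to compound 2 (beyond the scatter), changes the aryl on the same amide nitrogen. Compound 3 `COc1cc2c(cc1OC)C(CC(=O)Nc1ccncc1)CC2` differs from compound 2 by pyridin-4-yl in place of 3-methylphenyl on an amide-type nitrogen. Going by the values given here, no measured step covers an aryl with a ring nitrogen, so the single step offers no direction here, and a change within the scatter is the default expectation. The expected step is a number 6.7 percentage points lower from compound 2 to compound 3 (within the scatter). Compound 3 is estimated at 14%, between 0% and 30%.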

Compound 3, a percentage reported as inhibition, in the whole organism at one dose (the size of the read-out at that dose, not a potency): 19.7%
Beside the measured number, compound 3's estimate is 5.7 percentage points below it; low and high end bracket the measured number.
By their numbers in this assay, from the lowest: compound 1; then compounds 3 and 2 (each within the scatter of the next).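

In this assay, an aryl with a ring nitrogen on the amide nitrogen keeps the level set by 3-methylphenyl (a number 1 percentage points lower from compound 2 to compound 3 (within the scatter)). Pyridin-4-yl in place of 4-chlorophenyl gives a step beyond the scatter (a number 15 percentage points higher from compound 1 to compound 3 (beyond the scatter)), so compound 1 stands apart from both compound 2 and compound 3. Nothing at hand explains these steps. Open, from the compounds shown here alone, is whether this amide nitrogen accepts a group other than a single aromatic ring, such as benzyl or cyclohexyl. Also open, going by these compounds, is how pyridin-3-yl or 4-methylphenyl would compare.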